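Hydroxyphenyl position swap, second pair

The source may report more compounds than this note shows. Statements on the series, on what has been measured and on what is new or still open speak of the compounds shown alone.

Compound 1 `Oc1cccc(-c2cc(-c3ccoc3)cc(-c3cccc(O)c3)n2)c1` is measured in an assay on isolated protein for inhibition of DNA topoisomerase 1 (Homo sapiens), with a stated time of 30 min, tested at 20 uM (on this read-out higher numbers stand for a stronger effect at the one concentration tested and lower numbers for a weaker effect), and gives 2%. Compound 2 `Oc1ccc(-c2cc(-c3ccoc3)cc(-c3cccc(O)c3)n2)cc1` differs by 4-hydroxyphenyl in place of 3-hydroxyphenyl on an aromatic carbon and in this assay gives 1.3%; the step is a number 0.7 percentage points lower from compound 1 to compound 2 (within the scatter). Compound 3 `Oc1cccc(-c2cc(-c3cccnc3)cc(-c3ccccc3O)n2)c1` rests on another core; the difference between the two cores is not broken down here. In this assay compound 3 gives 0%. Compound 4 `Oc1ccc(-c2cc(-c3cccnc3)cc(-c3ccccc3O)n2)cc1` is not yet measured; it differs from compound 3 by 4-hydroxyphenyl in place of 3-hydroxyphenyl on an aromatic carbon, the same kind of change as the earlier one, though the surroundings differ: earlier the place is meta to a 3-hydroxyphenyl group and meta to a furan-3-yl group, here meta to a 2-hydroxyphenyl group and meta to a pyridin-3-yl group. For compound 4 a step of a number 0.5 percentage points higher from compound 3 to compound 4 (within the scatter) is expected, because a number 0.7 percentage points lower from compound 1 to compound 2 (within the scatter) lies within the scatter. Compound 4 is thus estimated at 0.5%, from -3% to 5%.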

Compound 4, a percentage reported as inhibition, at one concentration (the size of the read-out at that concentration, not a potency): 0%
For compound 4 the middle estimate is 0.5 percentage points above the measured one; low and high end bracket the measured number.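

With 4-hydroxyphenyl in place of 3-hydroxyphenyl, the new step is no change at the digits printed from compound 3 to compound 4 (within the scatter) in this assay. The change behaves alike on the two cores: the same change on two cores in this assay, a number 0.7 percentage points lower (within the scatter) from compound 1 to compound 2 and no change at the digits printed (within the scatter) from compound 3 to compound 4, 0.7 percentage points apart, within the scatter of two such steps This agreement holds only among compounds with very small read-outs at the one concentration tested, so it does not show that the step would carry over to a core with a clear effect, and it gives no size for such a step.

Going by these compounds, it remains open whether any compound of this series gives a read-out clear of the scatter in this assay. Also open, on these data alone, is how an amine or a carboxylic acid on the hydroxyphenyl rings, or in place of the furan-3-yl or pyridin-3-yl group, would read.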